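Aryl change on the shared core of compound 1

The source may report more compounds than this note shows. Statements on the series, on what has been measured and on what is new or still open speak of the compounds shown alone.

Compound 1 `CCCCCc1c(C(C)C)nc(C(C)C)c(CO)c1-c1ccccc1CO` gives 44% in an assay on CHO cells for inhibition of Glucagon receptor (Homo sapiens), tested at 20 uM (a higher number here means more inhibition at the concentration tested (going by the name of the read-out), a lower number less inhibition), the higher of the two numbers in hand. Compound 2 `CCCCCc1c(C(C)C)nc(C(C)C)c(CO)c1-c1ccc(C(F)(F)F)cc1` gives 35% in this assay, within the scatter of compound 1, so the pair shows no order. Compound 3 `CCCCCc1c(C(C)C)nc(C(C)C)c(CO)c1-c1cccc(Cl)c1` differs from compound 1 by 3-chlorophenyl in place of 2-(hydroxymethyl)phenyl on an aromatic carbon. Going by the values given here, no measured pair isolates this change. The step of a number 8 percentage points lower from compound 1 to compound 3 (within the scatter) is expected to stay within the scatter, if anything a small loss. Compound 3 is expected to give 36% in this assay, between 15% and 57%, because compound 2, also lacking the hydroxymethyl, gives 35%.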

Compound 3, a percentage reported as inhibition, at one concentration (the size of the read-out at that concentration, not a potency): 49%
Beside the measured number, compound 3's estimate is 13 percentage points below it; measured number inside the range.
By their numbers in this assay, from the lowest: compounds 2, 1 and 3 (each within the scatter of the next, the first and the last beyond it).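

In this assay, 3-chlorophenyl in place of 2-(hydroxymethyl)phenyl, on the aromatic carbon opposite the ring nitrogen, gives a number 5 percentage points higher from compound 1 to compound 3 (within the scatter). At this position, then, an aryl group with 0 hydrogen-bond donors and 0 hydrogen-bond acceptors reads the same as one carrying a hydroxymethyl. No measurement in hand bears on the reason for this step.

Still open, as far as these compounds go, is how an unsubstituted phenyl or an aryl group carrying an amine or a carboxylic acid would read here. Also open, from the compounds shown here alone, is whether a longer chain in place of the pentyl group would change the read-out.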